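Series notes: iodobenzamide on shared thiophene core, fluoro removal

The source may hold more compounds than are shown below. What is called first, only, known or untested is meant among the compounds shown, and "the series" means these compounds.

Compound 1 `COC(=O)c1scc(-c2ccc(NC(=O)c3cc(I)ccc3F)cc2)c1OC` has no number in a functional assay on HeLa cells (Homo sapiens) for antiproliferative activity, read by MTT assay, with a stated time of 24 h; a lower number here means a stronger inhibitor, a higher number a weaker inhibitor; the result for compound 1 in this assay reads "not determined" (no result reported). For the measured compounds named here, compound 2 `COC(=O)c1scc(-c2ccc(NC(=O)c3ccccn3)cc2)c1OC` is the only measured member of the set. In this assay compound 2 reaches only a limit, > 50000 nM, which is not a number. Going by the values given here, the single piece of evidence on the series is thus (the limit of > 50000 nM in this assay, at which 1 of the 2 values shown sits), and no measured step between two compounds exists. Compound 3 `COC(=O)c1scc(-c2ccc(NC(=O)c3cccc(I)c3)cc2)c1OC` differs from compound 1 as follows: hydrogen in place of fluoro on an aromatic carbon. Among the compounds with values here, with no measured step on record, no direction can be read from the data, and nothing beyond the usual scatter is expected for this change in this assay. The only anchor is the limit for compound 2, so the estimate for compound 3 in this assay is set at 30000 nM, expected between 3000 nM and 100000 nM, with a substantial chance that only a limit is reported.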

Compound 3, half-maximal inhibitory concentration: 12700 nM
For compound 3 the middle estimate is 2.4-fold (0.37 log units) above the measured one; the measured number falls inside the stated range.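

For the compounds shown here, compound 3 gives the only actual number so far, and it shows that activity in this assay can be reached on the shared core. With 3-iodophenyl in place of pyridin-2-yl on the carbonyl carbon, the data show an at least 3.9-fold lower number from compound 2 to compound 3 (0.59 log units; beyond the scatter), so this position responds to the group it carries. The true size of that step stays unknown, as one end of it is a limit and not a number: the limit of > 50000 nM in this assay, at which 1 of the 3 values shown sits.

From the compounds shown here alone, compound 1 has no result, so the change from 2-fluoro-5-iodophenyl to 3-iodophenyl cannot be read, and the role of the fluoro group stays open. The compounds shown also do not separate the iodo group from the change of ring, and whether an amine or a carboxylic acid in place of the iodo group would hold the activity is unknown.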